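From Cyclopentylmethyl to Cyclopropyl on a Shared Core

The source may hold more compounds than are shown below. What is called first, only, known or untested is meant among the compounds shown, and "the series" means these compounds.

Compound 1 `O=c1[nH]c(=O)n([C@H]2C[C@H](O)[C@@H](CO)O2)cc1C#CC#Cc1ccc([N+](=O)[O-])cc1`: 100000 nM
Compound 2 `O=c1[nH]c(=O)n([C@H]2C[C@H](O)[C@@H](CO)O2)cc1C#CC#CCC1CCCC1`: > 100000 nM

Both compounds were tested in an ADME assay on HEL cells (Homo sapiens) for cytotoxicity, read by microscopy; on this read-out lower numbers stand for higher toxicity in this test and higher numbers for lower toxicity in this test. Compound 1 gives 100000 nM. Compound 2 reaches only the limit of the test, > 100000 nM, so no exact number is known for it. Among the measured compounds shown here, the single measured step, a number no lower from compound 1 to compound 2 (the limit leaves the size open), puts cyclopentylmethyl in place of 4-nitrophenyl on a triple-bonded carbon; its size stays open because compound 2 sits at the limit of > 100000 nM in this assay, at which 1 of the 2 values shown sits.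

Compound 3 `O=c1[nH]c(=O)n([C@H]2C[C@H](O)[C@@H](CO)O2)cc1C#CC#CC1CC1` has not yet been measured and differs from compound 2 in one place: cyclopropyl in place of cyclopentylmethyl on a triple-bonded carbon. For the measured compounds named here, the only step that bears on this change is the one just described, and it gave no readable size. Compound 3 is therefore expected to remain near the limit, with the expected step being a number no higher from compound 2 to compound 3 (the limit leaves the size open), nothing beyond the scatter. The estimated value for compound 3 is 100000 nM, ranging from 40000 nM to 250000 nM.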

Compound 3, minimum cytotoxic concentration: > 100000 nM
Compound 3: only a limit was reported (the forecaster's own chance of this, stated with the estimate: 65%); the middle value sits exactly at the limit.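

In this assay compound 3 gives > 100000 nM, which is a limit and not an exact number. Cyclopropyl, with 3 heavy atoms, therefore ends at the same limit as cyclopentylmethyl, with 6 heavy atoms, so this smaller ring on the triple-bonded carbon brings no toxicity into view within the tested range. The change from 4-nitrophenyl gives a number no lower from compound 1 to compound 3 (the limit leaves the size open), but neither this step nor the one from cyclopentylmethyl to cyclopropyl has a readable size, because the values reach the end of the test's range: the limit of > 100000 nM in this assay, at which 2 of the 3 values shown sit.

From the compounds shown here alone, how far the number would move with a different group on this triple-bonded carbon remains open, since only compound 1 has an exact value here. An amine, a carboxylic acid or a longer chain at this place could show whether any such group gives a number clearly lower than these.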